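Butyl to 2,4-difluorophenyl on the sulfonyl sulfur

This account rests on a few compounds, and the source may have more. Where it says the series, first, only, none or still open, it means among the compounds named here.

For the measured compounds named here, in a functional assay on A549 cells (Homo sapiens) for antiproliferative activity, read by sulforhodamine B assay, with a stated time of 72 h (a higher number here means a weaker inhibitor, a lower number a stronger inhibitor), compound 2 `CCCCS(=O)(=O)Nc1cc(-c2ccc3ncnc(NCc4ccncc4)c3c2)cnc1OC` gives 9420 nM, the higher of the two numbers known so far. Compound 1 `CCCCS(=O)(=O)Nc1cc(-c2ccc3ncnc(NCCN(C)C)c3c2)cnc1OC` gives 1320 nM. Compound 3 `COc1ncc(-c2ccc3ncnc(NCc4ccncc4)c3c2)cc1NS(=O)(=O)c1ccc(F)cc1F` keeps the rest of compound 2 and carries 2,4-difluorophenyl in place of butyl on a sulfonyl sulfur. Going by the values given here, no measured step covers this change. The only one, a 7.1-fold higher number from compound 1 to compound 2 (0.85 log units; beyond the scatter), lies elsewhere, at pyridin-4-yl in place of (dimethylamino)methyl on a saturated chain carbon bound to a nitrogen on an aromatic ring, and serves only as a guide to size. A step of similar modest size is expected in this assay, tentatively towards a lower number, since the data do not fix the direction. The estimated change is a 3.1-fold lower number from compound 2 to compound 3 (0.50 log units; beyond the scatter). Compound 3 is expected at 3000 nM, within a range of 500 nM to 12000 nM.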

Compound 3, half-maximal inhibitory concentration: 11400 nM
Beside the measured number, compound 3's estimate is 3.8-fold (0.58 log units) below it; measured number inside the range.
By their numbers in this assay, from the lowest: compound 1; then compounds 2 and 3 (each within the scatter of the next).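

In this assay, for the compounds shown here, the sulfonyl sulfur carries either butyl or 2,4-difluorophenyl with a 1.2-fold higher number from compound 2 to compound 3 (0.08 log units; within the scatter), so this is the first reading at this position, and it separates the two groups by no more than the scatter. The open chain of four carbons and the six-membered aromatic ring therefore cannot be told apart here, at least with the pyridin-4-yl group in place, whereas the earlier step, at the saturated chain carbon, lay beyond the scatter. No supporting measurement accounts for this result.

As far as these compounds go, whether the same holds with the (dimethylamino)methyl group of compound 1 in place of pyridin-4-yl remains open. Also open, from the compounds shown here alone, is how a methyl group, an amine-bearing chain or a carboxylic acid on the sulfonyl sulfur would read in this assay.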